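The compounds below may be only part of what the source reports. "The series", "measured", "known", "first", "only" and "open" are said of these compounds alone.

Compound 1 `CC(/N=c1\c(O)c(O)\c1=N/c1cncc(Br)c1)C(C)(C)C`: 11700 nM
Compound 2 `CC(/N=c1\c(O)c(O)\c1=N/c1ccc(Br)cc1)C(C)(C)C`: 1260 nM

Among the compounds with values here, in a functional assay for inhibition, with Rattus norvegicus as the target (on this read-out lower numbers stand for stronger inhibition and higher numbers for weaker inhibition), compound 2 gives 1260 nM, the lower of the two numbers so far. Within the data shown here, the only measured step is a 9.3-fold lower number from compound 1 to compound 2 (0.97 log units; beyond the scatter), and it lies beyond the scatter. Compound 3 `CC(/N=c1\c(O)c(O)\c1=N/c1ccc(C#N)cc1)C(C)(C)C` differs from compound 2 in one place: cyano in place of bromo on an aromatic carbon. This is cyano in place of bromo on an aromatic carbon, para to a large group. The measured step changed something else, so it does not test this swap. It shows only how far one change has moved the number here. No measurement gives a direction for the swap, so a smaller step is expected, with only a tentative lean towards a lower number. The expected change is a 1.6-fold lower number from compound 2 to compound 3 (0.20 log units; within the scatter). In this assay the estimated value for compound 3 is 800 nM, with an expected range of 200 nM to 3000 nM.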

Compound 3, half-maximal inhibitory concentration: 520 nM
Compound 3: middle estimate off by 1.5-fold (0.19 log units), on the high side, and the stated range covers the measured number.
By their numbers in this assay, from the lowest: compound 3; then compound 2; then compound 1.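

In this assay, cyano in place of bromo on an aromatic carbon, para to a large group, gives a 2.4-fold lower number from compound 2 to compound 3 (0.38 log units; beyond the scatter). The earlier step exchanged 5-bromopyridin-3-yl for 4-bromophenyl, whereas this one keeps the six-membered aromatic ring of carbon only and changes just the group on it, showing that the number also responds to a change at this position. Bromo is therefore not required here for a number at this level, since cyano, with two heavy atoms and a hydrogen-bond acceptor by count, does better in this pair.

No measurement available here explains why the number falls. As far as these compounds go, whether an amine or a carboxylic acid at this same place would move the number further, and in which direction, remains open.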